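Swapping an imidazole for chlorophenyl on the sulfonyl

The source may report more compounds than this note shows. Statements on the series, on what has been measured and on what is new or still open speak of the compounds shown alone.

Four compounds share one core, a methylpiperidine joined to a second piperidine that carries a sulfonyl group, and differ only in the ring on that sulfonyl sulfur. Compound 1 `CC1CCN(C2CCN(S(=O)(=O)c3ccc(C#N)cc3)CC2)CC1` carries a 4-cyanophenyl there and in a functional assay on DLD-1 cells (Homo sapiens) for antiproliferative activity, read by CellTiter-Glo, with a stated time of 72 h (on this read-out higher numbers stand for weaker inhibition and lower numbers for stronger inhibition), compound 1 gives 2800 nM. Compound 2 `CC1CCN(C2CCN(S(=O)(=O)c3cccc(-c4ccccc4F)c3)CC2)CC1` carries a phenyl bearing a 2-fluorophenyl, and in this assay compound 2 gives 10 nM. Compound 3 `CC1CCN(C2CCN(S(=O)(=O)c3nccn3C)CC2)CC1` carries a 1-methyl-1H-imidazol-2-yl. In this assay compound 3 reaches only the limit of the assay, > 5000 nM, so no number is known for it. The step of an at least 1.7-fold higher number from compound 1 to compound 3 (0.25 log units; that floor lies within the scatter) therefore has only a floor, set by the limit of > 5000 nM in this assay, at which 1 of the 3 values shown sits.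

Compound 4 `CC1CCN(C2CCN(S(=O)(=O)c3cccc(Cl)c3)CC2)CC1` introduces the change (3-chlorophenyl in place of 1-methyl-1H-imidazol-2-yl on a sulfonyl sulfur). Among the compounds with values here, the one measured step touching this position, an at least 1.7-fold higher number from compound 1 to compound 3 (0.25 log units; that floor lies within the scatter), runs the other way and is open-ended, so it only suggests that leaving the imidazole should lower the number. Both phenyl-bearing compounds give numbers, not limits. Compound 4 is therefore expected to give 400 nM, between 60 nM and 3000 nM. That expectation means a step of an at least 12-fold lower number from compound 3 to compound 4 (1.09 log units; beyond the scatter).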

Compound 4, half-maximal inhibitory concentration: > 5000 nM
Compound 4: only a limit was reported (the forecaster's own chance of this, stated with the estimate: 5%); middle value at least 12-fold (1.09 log units) away from the limit.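

Compound 4 shows that a 3-chlorophenyl on the sulfonyl sulfur does not bring the number down from the limit in this assay, and a limit is all that is reported for it. Chloro in place of 2-fluorophenyl on an aromatic carbon gives an at least 500-fold higher number from compound 2 to compound 4 (2.69 log units; beyond the scatter), which ties the low number of compound 2 to that second ring, while 3-chlorophenyl in place of 4-cyanophenyl gives only an at least 1.7-fold higher number from compound 1 to compound 4 (0.25 log units; that floor lies within the scatter). The step between the imidazole and the 3-chlorophenyl cannot be read, since both ends are limits: the limit of > 5000 nM in this assay, at which 2 of the 4 values shown sit.

From the compounds shown here alone, how far above the limit compound 3 and compound 4 truly lie remains unknown. Going by these compounds, it is also open whether a pyridyl or a plain phenyl in place of the 2-fluorophenyl would keep the low number of compound 2.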